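Adding a Phenyl Group to Compound 2: Expected Growth Inhibition

The source may hold more compounds than are shown below. What is called first, only, known or untested is meant among the compounds shown, and "the series" means these compounds.

Of the compounds shown here, two sharing one core have been measured in a functional assay on OVCAR cells (Homo sapiens) for inhibition, read by MTT assay, with a stated time of 48 h; on this read-out higher numbers stand for weaker inhibition of growth and lower numbers for stronger inhibition of growth. Compound 1 `O=[N+]([O-])c1ccc(-c2cc(-c3ccccc3)n[nH]2)cc1` gives 7200 nM. For the measured compounds named here, compound 2 `COc1ccc(-c2cc(-c3ccccc3)n[nH]2)cc1` gives 9900 nM, the highest of the two numbers, though the only measured step, a 1.4-fold higher number from compound 1 to compound 2 (0.14 log units; within the scatter), lies within the scatter, so the two compounds cannot be ranked.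

Compound 3 `COc1ccc(-c2cc(-c3ccccc3-c3ccccc3)n[nH]2)cc1` differs from compound 2 in one place: phenyl in place of hydrogen on an aromatic carbon, placed ortho to a large group on a six-membered aromatic ring of carbon only. Going by the values given here, no measured step adds a phenyl group anywhere, and the one step that exists, a 1.4-fold higher number from compound 1 to compound 2 (0.14 log units; within the scatter), concerns a different ring and shows no effect beyond the scatter. It therefore offers no guide to this change. With nothing to point in either direction, compound 3 is expected to stay near compound 2, with the step of a 1.2-fold higher number from compound 2 to compound 3 (0.08 log units; within the scatter) estimated as small, giving an estimate of 12000 nM within a range from 4000 nM to 40000 nM.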

Compound 3, concentration for 50% growth inhibition: 670 nM
Compound 3: middle estimate off by 18-fold (1.25 log units), on the high side; measured number outside the range, below it.
By their numbers in this assay, from the lowest: compound 3; then compounds 1 and 2 (each within the scatter of the next).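

Phenyl in place of hydrogen on an aromatic carbon, ortho to a large group, gives a 15-fold lower number from compound 2 to compound 3 (1.17 log units; beyond the scatter) in this assay and so marks a stronger inhibition of growth. For the compounds shown here, this shows that the position responds strongly to this change, which the only earlier step, a 1.4-fold higher number from compound 1 to compound 2 (0.14 log units; within the scatter) on a different ring, could not reveal. Nothing shown here explains why the number falls so far.

Going by these compounds, it remains open whether this gain requires a phenyl ring, or whether a smaller group such as methyl, or a phenyl ring carrying an amine or a carboxylic acid, would do the same at this place. On these data alone, it also remains open whether the gain would persist with nitro in place of the methoxy group of compound 3.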